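Inverted stereocentre in the ring-fused ketone series

This account rests on a few compounds, and the source may have more. Where it says the series, first, only, none or still open, it means among the compounds named here.

In an assay for inhibition of Monoglyceride lipase (Mus musculus), with a stated time of 10 min (a lower number here means a stronger inhibitor, a higher number a weaker inhibitor), compound 1 `O=C(c1ncc(-c2ccccn2)o1)C1CCc2cc(Oc3ccccc3)ccc2O1` gives > 100000 nM; > 100000 nM (2 entries), a limit of the assay rather than a number, in each of its two entries. Compound 2 `O=C(c1ncc(-c2ccccn2)o1)[C@H]1COc2cc(Oc3ccccc3)ccc2C1` is the ring-fused analogue with one stereocentre drawn, and in this assay compound 2 gives > 100000 nM, again a limit of the assay and not a number; a further entry for compound 2 also yields no single number. Compound 2 thus stands at the limit of > 100000 nM in this assay, at which 1 of the 2 values shown sits. Compound 3 `O=C(c1ncc(-c2ccccn2)o1)[C@@H]1COc2cc(Oc3ccccc3)ccc2C1` keeps every atom and bond of compound 2 and differs only in configuration as drawn: the two compounds have the same atoms and bonds and differ only in configuration as drawn: 1 of 1 stereo elements differ; a stereocentre at a saturated ring carbon is drawn R in compound 2 and S in compound 3. Going by the values given here, no measured step is available for comparison, and with compound 1 and compound 2 both at the limit there is nothing in the numbers that points to a gain in this assay. The expected step from compound 2 to compound 3 is therefore a number no higher from compound 2 to compound 3 (the limit leaves the size open), none beyond the scatter. Compound 3 is expected to give 100000 nM, in the range 20000 nM to 300000 nM, most likely reported as a limit.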

Compound 3, half-maximal inhibitory concentration: > 100000 nM
Compound 3 was reported as a limit; the forecaster's own chance of this, stated with the estimate: 70%; the middle value sits exactly at the limit.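

In this assay, going by these compounds alone, compound 2 and compound 3 are both reported only as limits of the assay, so no step between them can be read: the limit of > 100000 nM in this assay, at which 2 of the 3 values shown sit.
The compounds shown leave open whether either configuration inhibits measurably, and whether the configuration as drawn makes any difference to inhibition.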